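The source may hold more compounds than are shown below. What is called first, only, known or untested is meant among the compounds shown, and "the series" means these compounds.

All the compounds here share one core, a cyclic urea linked through a benzene ring to a sulfonamide, and they differ only in the aromatic amine attached to that sulfonamide. Compound 1 `O=C1NCCN1c1ccc(S(=O)(=O)Nc2ccc3[nH]ccc3c2)cc1` carries a fused bicyclic amine, and in a functional assay on M21 cells (Homo sapiens) for antiproliferative activity, read by sulforhodamine B assay, with a stated time of 48 h (a lower number here means a stronger inhibitor, a higher number a weaker inhibitor), compound 1 gives 87 nM. Compound 3 `O=C1NCCN1c1ccc(S(=O)(=O)Nc2ccc3c(c2)CCC3)cc1` carries another fused bicyclic amine, and in this assay compound 3 gives 130 nM; the readings of compound 1 and compound 3 lie within the usual scatter of each other. Compound 2 `O=C1NCCN1c1ccc(S(=O)(=O)Nc2ccc(C3CCCCC3)cc2)cc1` carries a plain phenyl ring bearing a cyclohexyl group. For compound 2 the reading in this assay is only a limit of the assay, > 1000 nM, and not a number. Compound 2 therefore stands at the limit of > 1000 nM in this assay, at which 1 of the 3 values shown sits, clearly apart from the two measured values.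

For the measured compounds named here, the next compound, compound 4 `CCCCCCOc1ccc(NS(=O)(=O)c2ccc(N3CCNC3=O)cc2)cc1`, is the one change from compound 2 described as hexyloxy in place of cyclohexyl on an aromatic carbon. Going by the values given here, no measured step between compounds connects this change to a known shift, so the expectation rests on compound 2 alone. The step from compound 2 to compound 4 is expected to be small, a number no higher from compound 2 to compound 4 (the limit leaves the size open), with no clear direction beyond the scatter. Compound 4 is accordingly expected to give about 1000 nM, within a range from 300 nM to 3000 nM.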

Compound 4, half-maximal inhibitory concentration: > 1000 nM
Compound 4: a limit, no number; the forecaster's own chance of this, stated with the estimate: 50%; the middle value sits exactly at the limit.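

In this assay compound 4 gives > 1000 nM, which is a limit of the assay and not a number. Compound 2 also reads only as a limit, so no step from compound 2 to compound 4 can be read: the limit of > 1000 nM in this assay, at which 2 of the 4 values shown sit.

The compounds shown leave open whether hexyloxy and cyclohexyl differ at all in this assay.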